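This account rests on a few compounds, and the source may have more. Where it says the series, first, only, none or still open, it means among the compounds named here.

Measured in an assay on isolated protein for binding affinity to 5-hydroxytryptamine receptor 3A (Homo sapiens); a lower number here means a stronger inhibitor, a higher number a weaker inhibitor:
compound 1 `CNc1nc2c(C(=O)N[C@@H]3CN4CCC3CC4)cccc2o1` gives 36.4 nM
compound 2 `CCN(CC)c1nc2c(C(=O)N[C@@H]3CN4CCC3CC4)cccc2o1` gives 12.4 nM

Within the data shown here, compound 2 stands at the lower of the two numbers; the only other value is that of compound 1, the step being a 2.9-fold lower number from compound 1 to compound 2 (0.47 log units; beyond the scatter). Compound 3 `C[C@H]1COC[C@H](C)N1c1nc2c(C(=O)N[C@@H]3CN4CCC3CC4)cccc2o1` differs from compound 2 by 3,5-dimethylmorpholin-4-yl in place of diethylamino on an aromatic carbon. Among the measured compounds shown here, the single measured step that bears on this change, from methylamino to diethylamino, was modest and in the favourable direction. For the measured compounds named here, the 3,5-dimethylmorpholin-4-yl group has no measured precedent, so a step in this assay that stays near the scatter is expected, direction uncertain. Compound 3 is estimated at 15 nM, range 4 nM to 55 nM, meaning an expected step of a 1.2-fold higher number from compound 2 to compound 3 (0.08 log units; within the scatter).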

Compound 3, inhibition constant: 6.8 nM
Compound 3: the middle estimate sits 2.2-fold (0.34 log units) above what was measured; the measured number falls inside the stated range.
By their numbers in this assay, from the lowest: compounds 3 and 2 (each within the scatter of the next); then compound 1.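

In this assay, the position on the five-membered aromatic ring tolerates a ring in place of an open-chain amine: replacing diethylamino with 3,5-dimethylmorpholin-4-yl gives a 1.8-fold lower number from compound 2 to compound 3 (0.26 log units; within the scatter). Against methylamino, the same ring gives a 5.4-fold lower number from compound 1 to compound 3 (0.73 log units; beyond the scatter), so the advantage over the smaller amine is retained. No supporting data explain either step.

The compounds shown leave open whether the ring oxygen, the two methyl groups or the defined stereocentres matter. Unsubstituted morpholine and piperidine would be the closest comparisons at this position.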